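The source may report more compounds than this note shows. Statements on the series, on what has been measured and on what is new or still open speak of the compounds shown alone.

Measured in a functional assay on K562 cells (Homo sapiens) for cytotoxicity, read by MTT assay; a lower number here means a stronger inhibitor, a higher number a weaker inhibitor:
- Compound 1 `COc1ccc(/C=C/C(=O)c2ccc(OC)c3c2OC(C)(C)C=C3)cc1O`: 630 nM
- Compound 2 `C#CCOc1cc(/C=C/C(=O)c2ccc(OC)c3c2OC(C)(C)C=C3)ccc1OC`: > 10000 nM (a limit of the assay, not a number)
- Compound 3 `COc1ccc(/C=C/C(=O)c2ccc(OC)c3c2OC(C)(C)C=C3)cc1OC(=O)c1ccco1`: 450 nM

Only two of these compounds have actual numbers. Compound 3 gives 450 nM and stands level with compound 1 in this assay, as the measured step is a 1.4-fold lower number from compound 1 to compound 3 (0.15 log units; within the scatter). The value of compound 2 is a limit, recorded as the limit of > 10000 nM in this assay, at which 1 of the 3 values shown sits.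

The compound still to be measured is compound 4 `COc1ccc(/C=C/C(=O)c2ccc(OC)c3c2OC(C)(C)C=C3)cc1OS(=O)(=O)c1ccc(C)cc1`. Its difference from compound 3 is (4-methylphenyl)sulfonyl in place of (furan-2-yl)carbonyl on an oxygen on an aromatic ring, which puts (4-methylphenyl)sulfonyl in place of (furan-2-yl)carbonyl on an oxygen on an aromatic ring.

For the measured compounds named here, three measured steps concern this same oxygen, and they do not agree. The first is a 1.4-fold lower number from compound 1 to compound 3 (0.15 log units; within the scatter), while the second is an at least 15-fold higher number from compound 1 to compound 2 (1.20 log units; beyond the scatter). The third is an at least 22-fold lower number from compound 2 to compound 3 (1.34 log units; beyond the scatter). The entering group shares an aromatic ring with the (furan-2-yl)carbonyl of compound 3, which the propargyl of compound 2 lacks, so compound 3 is taken as the closer guide.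

The step expected in this assay is a 1.8-fold higher number from compound 3 to compound 4 (0.25 log units; within the scatter), a modest move towards a higher number and not one expected to pass beyond the scatter. The upper side of the range stays wide because of an at least 15-fold higher number from compound 1 to compound 2 (1.20 log units; beyond the scatter).

For compound 4 the estimate is 800 nM, with an expected range from 200 nM to 6000 nM.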

Compound 4, half-maximal inhibitory concentration: 7850 nM
Compound 4: middle estimate off by 9.8-fold (0.99 log units), on the low side; the measured number lies above the stated range.
By their numbers in this assay, from the lowest: compounds 3 and 1 (each within the scatter of the next); then compound 4. At a limit, above all of these: compound 2.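

In this assay, the swap at this oxygen gives a 17-fold higher number from compound 3 to compound 4 (1.24 log units; beyond the scatter), which shows that the (furan-2-yl)carbonyl and the (4-methylphenyl)sulfonyl are not interchangeable here, even though each carries an aromatic ring. Set against the hydrogen, the entering group gives a 12-fold higher number from compound 1 to compound 4 (1.10 log units; beyond the scatter), so among the groups shown, the (furan-2-yl)carbonyl of compound 3 is the only one on this oxygen that stands level with the hydrogen of compound 1, while the (4-methylphenyl)sulfonyl of compound 4 and the propargyl of compound 2 go against any idea that a group on this oxygen is generally tolerated. The value of compound 2 is a limit of the assay and not a number, so an at least 1.2-fold lower number from compound 2 to compound 4 (0.10 log units; that floor lies within the scatter) gives only a floor and does not set the (4-methylphenyl)sulfonyl apart from the propargyl: the limit of > 10000 nM in this assay, at which 1 of the 4 values shown sits.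

Compounds 3 and 4 differ in both the link on the oxygen and the ring it carries, so the compounds shown do not tell which of the two goes with the step. A benzoyl on this oxygen would keep the carbonyl link with a six-membered aromatic ring, and a methanesulfonyl would keep the sulfonyl link with no ring at all, so each would separate the two.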